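Methoxy on a dibenzylidene ketone: one step, repeated

The source may hold more compounds than are shown below. What is called first, only, known or untested is meant among the compounds shown, and "the series" means these compounds.

The study covers four compounds built on one cyclohexanone core carrying two arylidene arms, each arm bearing a nitro group on one aromatic ring. Compound 3 `O=C1/C(=C/c2ccccc2)CCC/C1=C\c1ccccc1[N+](=O)[O-]` is measured in a functional assay on L1210 cells (Mus musculus) for cytotoxicity, with a stated time of 48 h (on this read-out lower numbers stand for stronger inhibition and higher numbers for weaker inhibition), and gives 4840 nM. Compound 1 `COc1ccc(/C=C2\CCC/C(=C\c3ccccc3[N+](=O)[O-])C2=O)cc1` differs from it by methoxy in place of hydrogen on an aromatic carbon, and in this assay compound 1 gives 42400 nM. That single change made an 8.8-fold higher number from compound 3 to compound 1 (0.94 log units; beyond the scatter).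

Compound 2 `O=C1/C(=C/c2ccccc2)CCC/C1=C\c1ccc([N+](=O)[O-])cc1` has the same atoms as compound 3, joined differently; the difference between the two cores is not broken down here. In this assay compound 2 gives 9800 nM, which stands between the values of compound 3 and compound 1.

Compound 4 `COc1ccc(/C=C2\CCC/C(=C\c3ccc([N+](=O)[O-])cc3)C2=O)cc1` has not been measured. It differs from compound 2 by methoxy in place of hydrogen on an aromatic carbon, the same change that separates compound 3 from compound 1, with the same surroundings at the place of change. Because the earlier step gave an 8.8-fold higher number from compound 3 to compound 1 (0.94 log units; beyond the scatter), a step of similar direction is expected here, and compound 4 is expected to show a 4.6-fold higher number from compound 2 to compound 4 (0.66 log units; beyond the scatter) in this assay. This expectation rests on one pair only, so the estimate is kept wide. Compound 4 is estimated to give 45000 nM in this assay, within a range from 15000 nM to 130000 nM.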

Compound 4, half-maximal inhibitory concentration: 240000 nM
For compound 4 the middle estimate is 5.3-fold (0.73 log units) below the measured one; the whole stated range lies below it.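

In this assay, methoxy in place of hydrogen on an aromatic carbon again moved the number upward, with a 24-fold higher number from compound 2 to compound 4 (1.39 log units; beyond the scatter). The direction of the change therefore carried over from one core to the other, with the 4-methoxyphenyl compound giving the weaker inhibition in both pairs, but its size did not carry over: the same change on two cores in this assay, an 8.8-fold higher number (0.94 log units; beyond the scatter) from compound 3 to compound 1 and a 24-fold higher number (1.39 log units; beyond the scatter) from compound 2 to compound 4, 2.8-fold (0.45 log units) apart, beyond the scatter of two such steps. These two pairs establish the direction for these two cores only; they do not show what sets the two step sizes apart, and they offer no rule for predicting the size of the step on a further core.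

The compounds shown leave open whether another group in the same place, such as a hydroxyl group, an amine, a carboxylic acid or a longer chain such as ethoxy, would shift the number in the same direction on both cores, and whether the two steps would again differ in size. They also leave open what methoxy in place of hydrogen would do on the arm that carries the nitro group, on either core.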